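The compounds below may be only part of what the source reports. "The series", "measured", "known", "first", "only" and "open" are said of these compounds alone.

Measured so far:
compound 1, `CC(C)c1cccc(NC(=O)CCc2cccc3c2B(O)OC3)c1`: 1600 nM
compound 2, `COc1ccc(NC(=O)CCc2cccc3c2B(O)OC3)cc1OC`: > 100000 nM
compound 3, `O=C(CCc1cccc2c1B(O)OC2)Nc1cccc2ccccc12`: 150 nM

Three compounds share one core and differ only in the group attached to the amide nitrogen. In a functional assay on MDA-MB-231 cells (Homo sapiens) for antiproliferative activity, read by MTT assay, with a stated time of 72 h (a higher number here means a weaker inhibitor, a lower number a stronger inhibitor), compound 1 gives 1600 nM. Of the two numbers that are known, this is the higher one, so compound 1 is the weaker inhibitor of the pair. Compound 3 gives 150 nM in this assay, a clearly lower number, and the difference goes beyond the usual scatter. Compound 2 is reported only as a limit of this assay, > 100000 nM, and not as a number (the limit of > 100000 nM in this assay, at which 1 of the 3 values shown sits).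

Compound 4, `O=C(CCc1cccc2c1B(O)OC2)Nc1cccc(-c2ccc(C(F)(F)F)cc2)c1`, has not yet been measured. It differs from compound 1 in one place: 4-(trifluoromethyl)phenyl in place of isopropyl on an aromatic carbon. Compound 3, which carries a larger group built from aromatic rings, reaches a lower number than compound 1, and compound 4 likewise brings in a group that contains an aromatic ring.

A step from compound 1 to compound 4 toward a lower number, larger than the scatter, is therefore expected a 4.0-fold lower number from compound 1 to compound 4 (0.60 log units; beyond the scatter). For compound 4 in this assay the estimate is 400 nM, within a range from 100 nM to 2000 nM.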

Compound 4, half-maximal inhibitory concentration: 510 nM
The estimate for compound 4 lay 1.3-fold (0.11 log units) below the measured number; low and high end bracket the measured number.
By their numbers in this assay, from the lowest: compound 3; then compound 4; then compound 1. At a limit, above all of these: compound 2.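

On the shared core, the place on the aromatic ring that carries isopropyl in compound 1 tolerates a much bigger group: 4-(trifluoromethyl)phenyl brings 10 heavy atoms where isopropyl has 3, adds a six-membered aromatic ring, and gives a 3.1-fold lower number from compound 1 to compound 4 (0.50 log units; beyond the scatter) in this assay. This is the first pair shown that differs in only one place, so the change in number can be tied to this single exchange, which the earlier compounds could not do. The step is modest, but it lies beyond the usual scatter, so added bulk at this place does not cost activity in these cells and here goes along with a lower number.

Nothing shown explains why this exchange lowers the number. On these data alone, it also remains open whether the new aromatic ring alone accounts for the step, as a plain phenyl without the trifluoromethyl would show, and how an amine or a carboxylic acid on that ring would compare.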